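This account rests on a few compounds, and the source may have more. Where it says the series, first, only, none or still open, it means among the compounds named here.

In a functional assay on CHO cells with adenosine receptor A1 (Homo sapiens) as the target, read by cAMP accumulation and immunoassay, with a stated time of 6 min, tested at 10 uM (on this read-out higher numbers stand for a weaker effect at the one concentration tested and lower numbers for a stronger effect), compound 1 `Nc1scc(CN2CCN(c3ccc(OC(F)(F)F)cc3)CC2)c1C(=O)c1ccc(Cl)cc1` gives -74%, compound 2 `Nc1scc(CN2CCN(c3cccnc3)CC2)c1C(=O)c1ccc(Cl)cc1` gives -23%, and compound 3 `Nc1scc(CN2CCC(c3ccc(Cl)cc3)CC2)c1C(=O)c1ccc(Cl)cc1` gives -61%. Compound 2 thus stands highest of the three measured compounds, with compound 3 nearest and compound 1 furthest from it. Compound 4 `Nc1scc(CN2CCN(c3c(F)cccc3F)CC2)c1C(=O)c1ccc(Cl)cc1` differs from compound 2 in one place: 2,6-difluorophenyl in place of pyridin-3-yl on an amine nitrogen in a ring. Among the compounds with values here, one measured step bears on this change: a number 51 percentage points higher from compound 1 to compound 2 (beyond the scatter), where a six-membered aromatic ring of carbon only on the same ring nitrogen gave way to pyridin-3-yl. Going the other way, with 2,6-difluorophenyl entering in place of pyridin-3-yl, a large step downward, toward a stronger effect, is expected in this assay, namely a number 32 percentage points lower from compound 2 to compound 4 (beyond the scatter). Compound 4 is therefore estimated at -55%, within -80% to -25%.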

Compound 4, a percentage reported as activity, at one concentration (the size of the read-out at that concentration, not a potency): -80%
Compound 4: the middle estimate sits 25 percentage points above what was measured; the range from low to high includes it.
By their numbers in this assay, from the lowest: compounds 4 and 1 (each within the scatter of the next); then compound 3; then compound 2.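

In this assay, 2,6-difluorophenyl in place of pyridin-3-yl gives a number 57 percentage points lower from compound 2 to compound 4 (beyond the scatter), so the earlier contrast between pyridin-3-yl and a six-membered aromatic ring of carbon only now holds for two differently substituted rings on this amine nitrogen. These two carbon-only rings cannot be told apart, with a number 6 percentage points lower from compound 1 to compound 4 (within the scatter). No measurement offered here explains the change. The compounds shown leave open whether an unsubstituted phenyl ring would fall with these two rings or stay with pyridin-3-yl. They also leave open where a pyrimidin-5-yl ring would fall.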